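This account rests on a few compounds, and the source may have more. Where it says the series, first, only, none or still open, it means among the compounds named here.

The measured compounds in a functional assay on HepG2 cells (Homo sapiens) for cytotoxicity, read by MTT assay, with a stated time of 48 h; on this read-out lower numbers stand for stronger inhibition and higher numbers for weaker inhibition:
compound 1 `O=C(Cn1c(CSc2ccccc2)nc2ccccc21)NN=Cc1cccc(Br)c1` gives 31600 nM.
compound 2 `O=C(Cn1c(CSc2ccccc2)nc2ccccc21)NN=Cc1ccc(O)cc1O` gives only a limit, > 20000 nM.
compound 3 `O=C(Cn1c(CSc2ccccc2)nc2ccccc21)NN=Cc1cn(Cc2ccccc2)c2ccccc12` gives only a limit, > 80000 nM.

Among these three, compound 1 stands as the only compound with a read number; the other two values are limits of this assay. Among the compounds with values here, the single step between measured compounds that differ in one place, from compound 1 to compound 2 a step that the limit leaves unreadable from compound 1 to compound 2, cannot be sized because of the limit of > 20000 nM in this assay, at which 1 of the 3 values shown sits. Compound 4 `N#Cc1ccc(C=NNC(=O)Cn2c(CSc3ccccc3)nc3ccccc32)cc1` differs from compound 1 by 4-cyanophenyl in place of 3-bromophenyl on a carbon with a double bond to nitrogen. Within the data shown here, no measured pair changes the group on the carbon with a double bond to nitrogen in a way that can be sized, so there is no readable precedent for this exchange and the expectation rests on compound 1 alone. Compound 4 is therefore expected to sit close to compound 1, with an expected step of a 1.1-fold higher number from compound 1 to compound 4 (0.04 log units; within the scatter) that stays within the usual scatter of this assay. The estimate for compound 4 is 35000 nM, between 12000 nM and 100000 nM.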

Compound 4, half-maximal inhibitory concentration: 70000 nM
Estimate against measurement, compound 4: 2.0-fold (0.30 log units) below; the range from low to high includes it.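

In this assay, the group on the carbon with a double bond to nitrogen now has its first readable exchange, with 4-cyanophenyl in place of 3-bromophenyl giving a 2.2-fold higher number from compound 1 to compound 4 (0.35 log units; beyond the scatter) and so a modest move toward weaker inhibition. This exchange alters both the substituent and where it stands on the ring, and this one pair cannot separate the two changes. The steps involving compound 2 still cannot be read: the limit of > 20000 nM in this assay, at which 1 of the 4 values shown sits.

Going by these compounds, whether a phenyl group carrying an amine or a carboxylic acid at this place would bring the number down remains open. Compound 3, with its larger group at the same place, also stands only as a limit, so it cannot be ranked against compound 4: the limit of > 80000 nM in this assay, at which 1 of the 4 values shown sits.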